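This account rests on a few compounds, and the source may have more. Where it says the series, first, only, none or still open, it means among the compounds named here.

Compound 1 `Cc1noc(C)c1-c1cnc(N)c(Oc2ccc(C(=O)Nc3ccccc3Cl)cc2)n1` — in a functional assay on LoVo cells (Homo sapiens) for inhibition, read by MTT assay, with a stated time of 72 h (on this read-out lower numbers stand for stronger inhibition and higher numbers for weaker inhibition), compound 1 gives only a limit of the assay, > 100000 nM.
Compound 2 `Cc1noc(C)c1-c1cnc(N)c(Oc2ccc(C(=O)Nc3cccc(Cl)c3)cc2)n1` — in this assay compound 2 gives 1640 nM.
Compound 3 `Cn1cc(-c2cnc(N)c(Oc3ccc(C(=O)Nc4ccccc4Cl)cc3)n2)cn1` — in this assay compound 3 gives 41400 nM.
Compound 4 `Cn1cc(-c2cnc(N)c(Oc3ccc(C(=O)Nc4cccc(Cl)c4)cc3)n2)cn1` — not yet measured.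

Among the two real numbers, compound 3 stands highest, with compound 2 well below it. Compound 1 sits at the assay limit (the limit of > 100000 nM in this assay, at which 1 of the 3 values shown sits). Compound 4 differs from compound 3 by 3-chlorophenyl in place of 2-chlorophenyl on an amide-type nitrogen. The same change has been measured once, on a different core: an at least 60-fold lower number from compound 1 to compound 2 (1.78 log units; beyond the scatter), and that step reads as large. The other measured step, an at least 2.4-fold lower number from compound 1 to compound 3 (0.38 log units; beyond the scatter), concerns the core and not the chlorophenyl, so it bears less on this question. A large fall in the number for compound 4 is therefore expected, estimated as a 59-fold lower number from compound 3 to compound 4 (1.77 log units; beyond the scatter). Compound 4 is estimated at 700 nM, with a range from 200 nM to 2500 nM.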

Compound 4, half-maximal inhibitory concentration: 24500 nM
The estimate for compound 4 lay 35-fold (1.54 log units) below the measured number; the measured number lies above the stated range.
By their numbers in this assay, from the lowest: compound 2; then compounds 4 and 3 (each within the scatter of the next). At a limit, above all of these: compound 1.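

In this assay, 3-chlorophenyl in place of 2-chlorophenyl on the amide-type nitrogen gives a 1.7-fold lower number from compound 3 to compound 4 (0.23 log units; within the scatter), so the large gain on the core of compound 1 does not carry over to the core of compound 3: the same change on two cores in this assay, an at least 60-fold lower number (1.78 log units; beyond the scatter) from compound 1 to compound 2 and a 1.7-fold lower number (0.23 log units; within the scatter) from compound 3 to compound 4, at least 36-fold (1.55 log units) apart, beyond the scatter of two such steps
The core change also depends on the chlorophenyl group, with a 15-fold higher number from compound 2 to compound 4 (1.17 log units; beyond the scatter) running opposite to the earlier step: the same change on two cores in this assay, an at least 2.4-fold lower number (0.38 log units; beyond the scatter) from compound 1 to compound 3 and a 15-fold higher number (1.17 log units; beyond the scatter) from compound 2 to compound 4, at least 36-fold (1.55 log units) apart, beyond the scatter of two such steps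
Compound 1 gives only a limit, > 100000 nM, and both comparisons rest on it.

What lies behind this dependence stays open. So does whether it holds with a fluorine or a methoxy group in place of the chlorine.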